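The source may report more compounds than this note shows. Statements on the series, on what has been measured and on what is new or still open speak of the compounds shown alone.

Measured compounds in a functional assay on MCF7 cells (Homo sapiens) for antiproliferative activity, read by MTT assay, with a stated time of 72 h; on this read-out lower numbers stand for stronger inhibition and higher numbers for weaker inhibition:
- compound 1 `C/C(C#Cc1ccccc1)=N\N/C(N)=N/S(=O)(=O)c1cc(C)c(Cl)cc1SCc1ccccc1`: 110000 nM
- compound 2 `C/C(C#Cc1ccccc1)=N\N/C(N)=N/S(=O)(=O)c1cc(C)c(Cl)cc1SCc1ccccc1C(F)(F)F`: 19000 nM
- compound 3 `C/C(C#Cc1ccccc1)=N\N/C(N)=N/S(=O)(=O)c1cc(C)c(Cl)cc1SCc1cccc(C(F)(F)F)c1`: 20000 nM

Compound 3 stands second highest of the three numbers in this assay; its nearest neighbour is compound 2, the step of a 1.1-fold higher number from compound 2 to compound 3 (0.02 log units; within the scatter) lying within the scatter, while the step of a 5.5-fold lower number from compound 1 to compound 3 (0.74 log units; beyond the scatter) sets it well apart from compound 1.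

The next compound is compound 4 `C/C(C#Cc1ccccc1)=N\N/C(N)=N/S(=O)(=O)c1cc(C)c(Cl)cc1SCc1ccc(C(F)(F)F)cc1`, which differs from compound 3 only in 4-(trifluoromethyl)phenyl in place of 3-(trifluoromethyl)phenyl on a saturated chain carbon bound to a sulfur. Within the data shown here, no measured pair covers this particular change. What the series does show is that adding a trifluoromethyl group to the benzyl ring lowers the number by a modest amount at either position tried, a 5.8-fold lower number from compound 1 to compound 2 (0.76 log units; beyond the scatter) and a 5.5-fold lower number from compound 1 to compound 3 (0.74 log units; beyond the scatter), and that the two positions tried do not separate, a 1.1-fold higher number from compound 2 to compound 3 (0.02 log units; within the scatter). On that basis the move to the 4-(trifluoromethyl)phenyl group is expected to leave the number about where compound 3 sits, with no step beyond the scatter, a 1.1-fold lower number from compound 3 to compound 4 (0.05 log units; within the scatter). Compound 4 is therefore estimated at 18000 nM in this assay, with a range of 7000 nM to 45000 nM.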

Compound 4, half-maximal inhibitory concentration: 135000 nM
Estimate against measurement, compound 4: 7.5-fold (0.88 log units) below; measured number above the stated range.
By their numbers in this assay, from the lowest: compounds 2 and 3 (each within the scatter of the next); then compounds 1 and 4 (each within the scatter of the next).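

In this assay the steps of a 6.8-fold higher number from compound 3 to compound 4 (0.83 log units; beyond the scatter) and a 7.1-fold higher number from compound 2 to compound 4 (0.85 log units; beyond the scatter) show that the position of the trifluoromethyl group on the benzyl ring matters, although compound 2 and compound 3 gave no separation. With a 1.2-fold higher number from compound 1 to compound 4 (0.09 log units; within the scatter) there is no change on adding trifluoromethyl as the 4-(trifluoromethyl)benzyl group, so the gain over compound 1 holds for compound 2 and compound 3 only, and compound 4 goes against it. Nothing available accounts for this dependence on position.

Still open, from the compounds shown here alone, is whether a chlorine, a methoxy or a nitrile in place of trifluoromethyl would show the same dependence on position. Also open, going by these compounds, is whether a longer chain between the sulfur and the ring would keep the gap between compound 3 and compound 4.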